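Removing methylsulfanyl from compound 3: an expected outcome

The compounds below may be only part of what the source reports. "The series", "measured", "known", "first", "only" and "open" are said of these compounds alone.

Measured so far in a functional assay on HT-29 cells (Homo sapiens) for cytotoxicity, read by MTT assay, with a stated time of 72 h; on this read-out lower numbers stand for higher toxicity in this test and higher numbers for lower toxicity in this test:
compound 1 `CSc1ccc(CNc2nc(SC)nc3ncccc23)cc1` gives 8750 nM.
compound 2 `CCCCC[Se]c1nc(NCc2ccc(SC)cc2)c2ccccc2n1` reaches only a limit, > 100000 nM.
compound 3 `CSc1ccc(CNc2nc([SeH])nc3ccccc23)cc1` likewise reaches only a limit, > 100000 nM.

Compound 3 therefore stands at the limit of > 100000 nM in this assay, at which 2 of the 3 values shown sit, with no number of its own. Among the measured compounds shown here, the single one-place step measured, a step that the two limits leave unreadable from compound 2 to compound 3, involves a change on selenium and is itself unreadable. Compound 4 `[SeH]c1nc(NCc2ccccc2)c2ccccc2n1` differs from compound 3 in another place: hydrogen in place of methylsulfanyl on an aromatic carbon. For the measured compounds named here, no measured step touches this group, so no direction beyond the usual scatter can be read for this assay. Compound 4 is estimated at 100000 nM, within 20000 nM to 400000 nM. The expected step is a number no higher from compound 3 to compound 4 (the limit leaves the size open), most likely again a limit.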

Compound 4, concentration lethal to 50% of the cells: > 100000 nM
Compound 4 ended at the assay's limit; the forecaster's own chance of this, stated with the estimate: 70%; the middle value lies on the limit itself.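

Compound 3 and compound 4 both reach only a limit in this assay, so the step between them cannot be read: the limit of > 100000 nM in this assay, at which 3 of the 4 values shown sit.

On these data alone, whether methylsulfanyl makes any difference to toxicity in this test stays open.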